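From pyrrolidin-1-yl to piperidin-1-yl on a sulfonyl sulfur

The source may report more compounds than this note shows. Statements on the series, on what has been measured and on what is new or still open speak of the compounds shown alone.

In an ADME assay on microsomes from liver (Mus musculus) for metabolic stability, tested at 5 uM (a lower number here means that the compound disappears faster, a higher number that the compound lasts longer), compound 1 (`COCCCCNc1ccc(C(=O)O)cc1S(=O)(=O)N(C)C`) reads > 1 h as a limit, not a number. Compound 2 (`CNS(=O)(=O)c1cc(C(=O)O)ccc1NCCCCCCCC(F)(F)F`) reads > 1 h as a limit too. Compound 3 (`O=C(O)c1ccc(NCCCCCCCC(F)(F)F)c(S(=O)(=O)N2CCCC2)c1`) also reads > 1 h as a limit, so it has no exact value. The three compounds share the limit of > 1 h in this assay, at which 3 of the 3 values shown sit, as their result. Compound 4 (`O=C(O)c1ccc(NCCCCCCCC(F)(F)F)c(S(=O)(=O)N2CCCCC2)c1`) differs from compound 3 by piperidin-1-yl in place of pyrrolidin-1-yl on a sulfonyl sulfur in one place, with piperidin-1-yl in place of pyrrolidin-1-yl on a sulfonyl sulfur. For the measured compounds named here, the one measured step at this place is a step that the two limits leave unreadable from compound 2 to compound 3 and offers no size to carry over. In this assay the expected change is a step that the limit leaves unreadable from compound 3 to compound 4 and no more than the usual scatter. Compound 4 is estimated at 1.5 h within a range from 0.8 h to 3 h and may well come out only as a limit.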

Compound 4, half-life: > 1 h
Compound 4 was reported as a limit; the forecaster's own chance of this, stated with the estimate: 80%; the middle value lies beyond the limit too.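

No step can be read among compound 2, compound 3 and compound 4 in this assay, since each result is a limit and not a number: the limit of > 1 h in this assay, at which 4 of the 4 values shown sit.

The compounds shown leave open how long each one actually lasts, and whether methylamino, pyrrolidin-1-yl or piperidin-1-yl on the sulfonyl sulfur changes the half-life at all.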